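Changing the aryl group on the weakest compound

The source may report more compounds than this note shows. Statements on the series, on what has been measured and on what is new or still open speak of the compounds shown alone.

Compound 1 `CCCCCCCCc1ccc(OCC(=O)Cn2nnc(C)n2)cc1` gives 27 nM in an assay on microsomes from brain for inhibition of Fatty-acid amide hydrolase 1 (Rattus norvegicus), read by fluorescence and HPLC, with a stated time of 60 min; a lower number here means a stronger inhibitor, a higher number a weaker inhibitor. Compound 2 `CCCCCCCCc1ccc(OCC(=O)Cn2nnc(C(=O)OC)n2)cc1` gives 88 nM in this assay, a step of a 3.3-fold higher number from compound 1 to compound 2 (0.51 log units; beyond the scatter). Compound 3 `CCCCCCCCc1ccc(OCC(=O)Cn2nnnc2-c2ccc(S(=O)(=O)N(C)C)cc2)cc1` gives 1400 nM in this assay, the weakest of the three, its distance to compound 2 and to compound 1 each beyond the scatter. Compound 4 `CCCCCCCCc1ccc(OCC(=O)Cn2nnnc2-c2cccc(C(=O)O)c2)cc1` differs from compound 3 in one place: 3-carboxyphenyl in place of 4-(dimethylsulfamoyl)phenyl on an aromatic carbon. Within the data shown here, no measured step covers an exchange of one aryl substituent for another; the single step available, a 3.3-fold higher number from compound 1 to compound 2 (0.51 log units; beyond the scatter), concerns a different part of the shared core and offers little guidance. The expected step is therefore a 1.2-fold lower number from compound 3 to compound 4 (0.07 log units; within the scatter), within the scatter. Compound 4 is estimated at 1200 nM, with a range from 300 nM to 5000 nM.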

Compound 4, half-maximal inhibitory concentration: 1800 nM
Estimate against measurement, compound 4: 1.5-fold (0.18 log units) below, within the range that was stated.
By their numbers in this assay, from the lowest: compound 1; then compound 2; then compounds 3 and 4 (each within the scatter of the next).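

Putting 3-carboxyphenyl in place of 4-(dimethylsulfamoyl)phenyl on this aromatic carbon gives a 1.3-fold higher number from compound 3 to compound 4 (0.11 log units; within the scatter) in this assay. Among these compounds, the two aryl groups therefore cannot be told apart here, even though they differ in heavy atoms and hydrogen-bond donors, and the earlier compounds held no such exchange of one aryl group for another. No measurement at hand explains this match. Still open, on these data alone, is whether a plain phenyl or a benzylamine group on this same carbon would read like these two, or would differ from them beyond the scatter.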